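Thiourea Variants on a Phenylpyridazinone Chain

The compounds below may be only part of what the source reports. "The series", "measured", "known", "first", "only" and "open" are said of these compounds alone.

Measured compounds:
compound 1, `CC/N=C(/NC#N)NCCCCn1nc(-c2ccccc2)ccc1=O`, 58.8%
compound 2, `C=CCNC(=S)NCCCCn1nc(-c2ccccc2)ccc1=O`, 27.1%

For the measured compounds named here, in a functional assay on the whole organism with Rattus norvegicus as the target, at a dose of 100 mg/kg (on this read-out higher numbers stand for more inhibition at the one dose given (going by the name of the read-out) and lower numbers for less inhibition), compound 2 gives 27.1%, the lower of the two numbers; the only neighbour is compound 1 with 58.8%, and the step of a number 31.7 percentage points lower from compound 1 to compound 2 (beyond the scatter) is large. Compound 3, `C/N=C(\S)N(C)CCCCn1nc(-c2ccccc2)ccc1=O`, differs from compound 2 by a group of 6 heavy atoms (3 carbon, 2 nitrogen, 1 sulfur; no ring) in place of a group of 7 heavy atoms (4 carbon, 2 nitrogen, 1 sulfur; no ring), on a saturated chain carbon, four bonds along the chain from an aromatic nitrogen. Going by the values given here, the one measured step shows that the end group on this chain moves the read-out far, but no step of the same kind exists, so the direction is open. Compound 3 is estimated at 33% (range 10% to 60%), a step of a number 5.9 percentage points higher from compound 2 to compound 3 (within the scatter) that is expected to stay within the scatter.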

Compound 3, a percentage reported as inhibition, in the whole organism at one dose (the size of the read-out at that dose, not a potency): 17.5%
For compound 3 the middle estimate is 15.5 percentage points above the measured one, and the stated range covers the measured number.
By their numbers in this assay, from the lowest: compounds 3 and 2 (each within the scatter of the next); then compound 1.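

In this assay the exchange of the end group on the saturated chain carbon, four bonds along the chain from an aromatic nitrogen, gives a number 9.6 percentage points lower from compound 2 to compound 3 (within the scatter), so these two sulfur-bearing end groups are not told apart. The wider exchange gives a number 41.3 percentage points lower from compound 1 to compound 3 (beyond the scatter), which sets compound 3 clearly apart from compound 1 as well, as compound 2 already was. No measurement offered here explains these results. From the compounds shown here alone, whether a urea or an amine at the chain end would match compound 1 stays open, as does the effect of a longer chain.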